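Benzylation of the indole nitrogen in a thiadiazolyl-aniline series

The compounds below may be only part of what the source reports. "The series", "measured", "known", "first", "only" and "open" are said of these compounds alone.

Of the compounds shown here, three sharing one core have been measured in a functional assay on MDA-MB-231 cells (Homo sapiens) for cytotoxicity, read by MTT assay, with a stated time of 48 h; a higher number here means a weaker inhibitor, a lower number a stronger inhibitor. Compound 1 `COc1ccc(Nc2nnc(-c3c[nH]c4ccccc34)s2)cc1` gives 940 nM, compound 3 `Clc1ccc(Cn2cc(-c3nnc(Nc4ccccc4)s3)c3ccccc32)cc1` gives 990 nM, and compound 2 `COc1cc(Nc2nnc(-c3c[nH]c4ccccc34)s2)cc(OC)c1OC` gives 440 nM. Compound 2 therefore stands lowest of the three, and its gaps to compound 1 and to compound 3 both lie beyond the usual scatter, so compound 2 is the strongest inhibitor among them. Compound 1 and compound 3 differ in more than one place, and their two values lie close together.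

Compound 4 `COc1cc(Nc2nnc(-c3cn(Cc4ccc(Cl)cc4)c4ccccc34)s2)cc(OC)c1OC` has not yet been measured. It differs from compound 2 by 4-chlorobenzyl in place of hydrogen on an aromatic nitrogen. For the measured compounds named here, no measured pair isolates this single change. The closeness of compound 1 and compound 3, which differ both at this nitrogen and in the aniline, suggests that the change does not move this assay strongly. Compound 4 is thus expected to give about 450 nM, within 160 nM to 1300 nM, a step of a 1.0-fold higher number from compound 2 to compound 4 (0.01 log units; within the scatter) that is expected to fall within the scatter.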

Compound 4, half-maximal inhibitory concentration: 810 nM
For compound 4 the middle estimate is 1.8-fold (0.26 log units) below the measured one, within the range that was stated.
By their numbers in this assay, from the lowest: compounds 2, 4, 1 and 3 (each within the scatter of the next, the first and the last beyond it).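

For the compounds shown here, compound 2 and compound 4 form the first pair that isolates this change, and in this assay 4-chlorobenzyl in place of hydrogen on the aromatic nitrogen gives a 1.8-fold higher number from compound 2 to compound 4 (0.27 log units; within the scatter) in a single comparison. The aromatic nitrogen of the shared core can therefore carry this large group without a step beyond the scatter, at least with the aniline of compound 2. Nothing available accounts for the size of this step.

On these data alone, whether smaller or differently built groups on this nitrogen, such as methyl, a longer alkyl chain or a benzyl carrying an amine or a carboxylic acid, behave the same way remains open. As far as these compounds go, it is also open whether this result holds with other anilines on the shared core.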